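The source may report more compounds than this note shows. Statements on the series, on what has been measured and on what is new or still open speak of the compounds shown alone.

Measured compounds:
Compound 1 `O=C(Nc1cc(-c2ccccc2)nn1-c1ccccc1)c1cccc(C(F)(F)F)c1` – in an assay on HEK293 cells for displacement of a labelled ligand from metabotropic glutamate receptor 5 (Rattus norvegicus) (on this read-out lower numbers stand for stronger inhibition and higher numbers for weaker inhibition), compound 1 gives 1650 nM.
Compound 2 `O=C(Nc1cc(-c2ccccc2)nn1-c1ccccc1)c1ccncc1` – in this assay compound 2 reaches only a limit, > 10000 nM, which is the limit of > 10000 nM in this assay, at which 1 of the 2 values shown sits.

Compound 2 thus stands at the weak end of the numbers shown, as a limit and not a number. Within the data shown here, the only measured step, an at least 6.0-fold higher number from compound 1 to compound 2 (0.78 log units; beyond the scatter), runs from a number into that limit. Compound 3 `O=C(CC1CCCC1)Nc1cc(-c2ccccc2)nn1-c1ccccc1` differs from compound 2 by cyclopentylmethyl in place of pyridin-4-yl on a carbonyl carbon. Among the measured compounds shown here, no measured step exchanges an aromatic ring on the carbonyl carbon for a non-aromatic one, so the direction is open. Compound 3 is expected near 6000 nM, range 1500 nM to 20000 nM, an estimated step of an at least 1.6-fold lower number from compound 2 to compound 3 (0.22 log units; that floor lies within the scatter).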

Compound 3, inhibition constant: > 10000 nM
Compound 3: a limit, no number (the forecaster's own chance of this, stated with the estimate: 40%); middle value at least 1.6-fold (0.22 log units) from the limit.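

Cyclopentylmethyl on the carbonyl carbon gives an at least 6.0-fold higher number from compound 1 to compound 3 (0.78 log units; beyond the scatter), so in this assay a non-aromatic ring of carbon only, like pyridin-4-yl, falls short of the number held by 3-(trifluoromethyl)phenyl. Of the three groups at this position, only 3-(trifluoromethyl)phenyl gives a number. The step between compound 2 and compound 3 cannot be read, as each value is a limit and not a number: the limit of > 10000 nM in this assay, at which 2 of the 3 values shown sit.

From the compounds shown here alone, whether an unsubstituted phenyl or a phenyl carrying a nitrile would give a number at this position remains open. Going by these compounds, how far compound 2 and compound 3 lie beyond the limit also remains open.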